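From Dimethoxyphenyl to Methyl: Estimating Compound 3

A few compounds are considered here, and "the series" means these few. Any claim that something is new, unique, unknown or untested is made for them only; others in the source may bear on it.

Measured so far:
- compound 1 `CCN(CC)CCCN(C(=O)c1ccc(-c2ccccc2)[nH]1)C(C(=O)NC1CCCCC1)c1ccc(O)cc1`: 1320 nM
- compound 2 `CCN(CC)CCCN(C(=O)c1ccc(-c2ccccc2)[nH]1)C(C(=O)NC1CCCCC1)c1ccc(OC)c(OC)c1`: 2630 nM

Both numbers come from an assay on isolated protein for binding affinity to growth hormone secretagogue receptor type 1 (Homo sapiens); on this read-out lower numbers stand for stronger inhibition and higher numbers for weaker inhibition. Compound 2 gives the higher of the two numbers, but the step of a 2.0-fold higher number from compound 1 to compound 2 (0.30 log units; within the scatter) is within the scatter, so the two compounds cannot be told apart on this read-out.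

Compound 3 `CCN(CC)CCCN(C(=O)c1ccc(-c2ccccc2)[nH]1)C(C)C(=O)NC1CCCCC1` differs from compound 2 in one place: methyl in place of 3,4-dimethoxyphenyl on a saturated chain carbon bound to an amide-type nitrogen and a carbonyl carbon. Here the whole aromatic ring with its two methoxy groups is gone and only a single carbon remains at that position.

Among the measured compounds shown here, the only measured step, from compound 1 to compound 2, exchanges one aromatic ring for another and stays within the scatter; it says nothing about removing the ring altogether. For the measured compounds named here, no measured pair covers a change of this kind, so the expectation rests on little. Because a 2.0-fold higher number from compound 1 to compound 2 (0.30 log units; within the scatter) shows the two aryl variants behaving alike, the large change to methyl is treated as a step into unknown territory, and a weaker number is expected, with a wide range.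

The estimate for compound 3 in this assay is 8000 nM (range 2000 nM to 40000 nM), meaning an expected step of a 3.0-fold higher number from compound 2 to compound 3 (0.48 log units; beyond the scatter).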

Compound 3, inhibition constant: 1920 nM
Compound 3: middle estimate off by 4.2-fold (0.62 log units), on the high side; the whole stated range lies above it.
By their numbers in this assay, from the lowest: compounds 1, 3 and 2 (each within the scatter of the next).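

In this assay replacing the 3,4-dimethoxyphenyl with methyl gives a 1.4-fold lower number from compound 2 to compound 3 (0.14 log units; within the scatter) and replacing the 4-hydroxyphenyl with methyl gives a 1.5-fold higher number from compound 1 to compound 3 (0.16 log units; within the scatter) on this read-out. Among the compounds shown here, the earlier pair showed only that one aromatic ring could stand in for another on a saturated chain carbon bound to an amide-type nitrogen and a carbonyl carbon, whereas these steps show that a group of 10 heavy atoms can give way to a single carbon and the compounds still cannot be told apart. Across these three compounds, then, an aromatic ring at this place is not needed to keep the number in this range, and nothing available here explains that result.

On these data alone, it remains open whether a bare hydrogen, a longer chain such as butyl, an amine or a carboxylic acid at this place would move the number beyond the scatter. All three compounds also share the rest of the core, so they cannot show whether the same tolerance would hold if another part of the molecule were changed.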